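Methyl added to the ring of compound 1

The compounds below may be only part of what the source reports. "The series", "measured", "known", "first", "only" and "open" are said of these compounds alone.

- compound 1 `CC1=C(c2cccc(O)c2)C(c2ccc(OC[C@H](C)N3CCCC3)cc2)Oc2ccc(O)cc21`: 0.2 nM
- compound 2 `CC1=C(c2ccc(C#N)cc2)C(c2ccc(OC[C@H](C)N3CC[C@@H](C)C3)cc2)Oc2ccc(O)cc21`: 10 nM
- compound 3 `CC1=C(c2cccc(S(C)(=O)=O)c2)C(c2ccc(OC[C@H](C)N3CC[C@@H](C)C3)cc2)Oc2ccc(O)cc21`: 4.3 nM

In a functional assay on MCF7 cells (Homo sapiens) for antiproliferative activity, read by CellTiter-Glo, with a stated time of 5 days (a lower number here means a stronger inhibitor, a higher number a weaker inhibitor), compound 1 has the lowest number of the three. Compound 4 `CC1=C(c2cccc(O)c2)C(c2ccc(OC[C@@H](C)N3CC[C@@H](C)C3)cc2)Oc2ccc(O)cc21` differs from it by one change: a group of 8 heavy atoms (7 carbon, 1 nitrogen; one five-membered non-aromatic ring with 1 hetero atom) in place of a group of 7 heavy atoms (6 carbon, 1 nitrogen; one five-membered non-aromatic ring with 1 hetero atom), on a saturated chain carbon bound to an oxygen on an aromatic ring. Going by the values given here, the only measured step, a 2.3-fold lower number from compound 2 to compound 3 (0.37 log units; beyond the scatter), lies elsewhere and does not test this change. Compound 3, which carries a similar group of 8 heavy atoms, gives 4.3 nM, but it also differs from compound 1 on the double-bonded ring carbon. This points only loosely to a higher number. The expected step is a 5.0-fold higher number from compound 1 to compound 4 (0.70 log units; beyond the scatter), a modest weakening. For compound 4 the estimated value is 1 nM, with an expected range from 0.2 nM to 6 nM.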

Compound 4, half-maximal inhibitory concentration: 0.2 nM
Estimate against measurement, compound 4: 5.0-fold (0.70 log units) above, and the stated range covers the measured number.
By their numbers in this assay, from the lowest: compounds 1 and 4 (each within the scatter of the next); then compound 3; then compound 2.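

In this assay, swapping in the group of 8 heavy atoms on the saturated chain carbon bound to an oxygen on an aromatic ring gives no change at the digits printed from compound 1 to compound 4 (within the scatter), so this position accepts that group with its 2 defined stereocentres. Compounds 2 and 3 could not show this, since both also differ from compound 1 on the double-bonded ring carbon. No measurement at hand bears on why the number holds.

The compounds shown leave open what each stereocentre contributes on its own. They also leave open whether a piperidine ring or an open-chain diethylamino group would read the same in this place.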